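From Chloro to Trifluoromethyl: A Small Shift Expected

The source may report more compounds than this note shows. Statements on the series, on what has been measured and on what is new or still open speak of the compounds shown alone.

Of the compounds shown here, two have so far been measured in an assay on 1321N1 cells for antagonist activity at P2Y purinoceptor 6 (Homo sapiens), read by FLIPR and calcium flux; on this read-out lower numbers stand for stronger inhibition and higher numbers for weaker inhibition. Compound 1 `O=[N+]([O-])C1=Cc2cc(C#Cc3ccc(F)cc3)ccc2OC1C(F)(F)F` gives 8860 nM. Compound 2 `O=[N+]([O-])C1=Cc2cc(C#Cc3ccc(Cl)cc3)ccc2OC1C(F)(F)F` gives 5350 nM in this assay, the lowest of the two numbers recorded; the step of a 1.7-fold lower number from compound 1 to compound 2 (0.22 log units; within the scatter) separates them and lies within the scatter. Compound 3 `O=[N+]([O-])C1=Cc2cc(C#Cc3ccc(C(F)(F)F)cc3)ccc2OC1C(F)(F)F` has not yet been measured. It differs from compound 2 in one place: trifluoromethyl in place of chloro on an aromatic carbon. For the measured compounds named here, the only measured step that bears on this change is the one already described, which exchanged one halogen for another at the same place and stayed within the scatter. The new exchange is of a similar kind, so in this assay a step no larger than the scatter is expected, with no clear direction. On that basis compound 3 is estimated at 4500 nM, with a range from 1500 nM to 13000 nM, which would mean an expected step of a 1.2-fold lower number from compound 2 to compound 3 (0.08 log units; within the scatter).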

Compound 3, half-maximal inhibitory concentration: 5220 nM
Beside the measured number, compound 3's estimate is 1.2-fold (0.06 log units) below it; the range from low to high includes it.
By their numbers in this assay, from the lowest: compounds 3, 2 and 1 (each within the scatter of the next).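

Trifluoromethyl brings 4 heavy atoms to a place that chloro fills with 1, yet in this assay this exchange gives a 1.0-fold lower number from compound 2 to compound 3 (0.01 log units; within the scatter) and so stays inside the usual noise. The exchange for fluoro gives a 1.7-fold lower number from compound 1 to compound 3 (0.23 log units; within the scatter) and also stays inside it, so on this aromatic carbon, para to a large group, the readings for all three groups lie within the scatter of one another, now including a group of several atoms and not just single halogens. Nothing available explains why these readings lie so close.

On these data alone, all three compounds carry a small group without hydrogen-bond donors or acceptors here, so what an amine, a carboxylic acid or a longer chain would give at this place remains open. As far as these compounds go, whether changes elsewhere on the shared core would read differently also remains open.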